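Trading a Silyl Ether for a Formyl Group

The source may report more compounds than this note shows. Statements on the series, on what has been measured and on what is new or still open speak of the compounds shown alone.

Compound 1 `Cn1nc(Cc2nnc(SCC(=O)Nc3ccc(Cl)cc3Cl)n2CCC=O)c2ccccc2c1=O` in an assay on 32D cells for inhibition of interleukin-15 (Mus musculus), read by resazurin assay, with stated times of 30 min and 2.5 days, in the presence of a further agent that is not named here (a lower number here means a stronger inhibitor, a higher number a weaker inhibitor), gives 6400 nM.
Compound 2 `Cn1nc(Cc2nnc(SCC(=O)Nc3ccc(Cl)cc3Cl)n2CCCO)c2ccccc2c1=O` gives only a limit, > 30000 nM.
Compound 3 `Cn1c(Cc2nn(CCCO[Si](C)(C)C(C)(C)C)c(=O)c3ccccc23)nnc1SCCCCCCCC(=O)Nc1ccc(Cl)cc1Cl` likewise gives only a limit, > 30000 nM.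

Compound 3 therefore stands at the limit of > 30000 nM in this assay, at which 2 of the 3 values shown sit, with no number to place it against compound 1. Compound 4 `Cn1c(Cc2nn(CCC=O)c(=O)c3ccccc23)nnc1SCCCCCCCC(=O)Nc1ccc(Cl)cc1Cl` differs from it in one place: a group of 2 heavy atoms (1 carbon, 1 oxygen; no ring) in place of a group of 9 heavy atoms (7 carbon, 1 oxygen, 1 silicon; no ring), on a saturated chain carbon, two bonds along the chain from an aromatic nitrogen. Going by the values given here, one measured step touches the same position. The step of an at least 4.6-fold higher number from compound 1 to compound 2 (0.67 log units; beyond the scatter) moved the number in the weaker direction when formyl gave way to hydroxymethyl. Compound 4 moves toward formyl, so the direction, if anything, points to a stronger inhibitor than compound 3, but the group leaving here is a silyl ether rather than hydroxymethyl, and the chain between the sulfur and the amide is longer than in compound 1, so that step is only a loose guide. The number for compound 4 is expected to fall to about 15000 nM, somewhere between 4000 nM and 40000 nM, which would be the estimated step of an at least 2.0-fold lower number from compound 3 to compound 4 (0.30 log units; that floor lies within the scatter); a limit again is well possible.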

Compound 4, half-maximal inhibitory concentration: 11700 nM
Compound 4: middle estimate off by 1.3-fold (0.11 log units), on the high side; the range from low to high includes it.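

Replacing the silyl ether group with formyl, on a saturated chain carbon, two bonds along the chain from an aromatic nitrogen, gives an at least 2.5-fold lower number from compound 3 to compound 4 (0.40 log units; beyond the scatter). The earlier step compared formyl only with hydroxymethyl; this one shows that formyl also goes with a lower number than a much larger group, and does so in a compound whose chain from the sulfur to the amide is longer than in compound 1. Compound 3 gives only a limit, so the size of this step is a floor and not an exact measure: the limit of > 30000 nM in this assay, at which 2 of the 4 values shown sit.

The compounds shown leave open whether formyl itself matters here or whether losing the silyl ether is enough, which a plain hydroxymethyl on the chain of compound 4 could help to separate. They also do not say how an amine or a carboxylic acid in the same place would read.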